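The compounds below may be only part of what the source reports. "The series", "measured", "known", "first", "only" and "open" are said of these compounds alone.

Measured compounds and values in a functional assay on the whole organism with Rattus norvegicus as the target, with a stated time of 5 days; on this read-out lower numbers stand for an effect already at smaller amounts and higher numbers for an effect only at larger amounts of compound:
compound 1, `CN1CCC/C1=N\C(=O)Nc1ccccc1`: 15 mg/kg
compound 2, `CN1CCC/C1=N\C(=O)Nc1c(Br)cccc1Br`: a limit of > 25 mg/kg
compound 3, `Cc1cccc(Cl)c1NC(=O)/N=C1\CCCN1C`: a limit of > 25 mg/kg

For the measured compounds named here, compound 1 is the only member of this set for which this assay returns a number at all; compound 1 reaches an effect at 15 mg/kg. The two other values are not numbers but limits of the assay. Compound 2 gives only > 25 mg/kg in this assay. Compound 3 likewise gives only > 25 mg/kg. Going by the values given here, both of these sit at the limit of > 25 mg/kg in this assay, at which 2 of the 3 values shown sit, so compound 1 stands alone as the one compound with a defined minimum effective dose, and no step between measured compounds can be stated.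

Compound 4, `CN1CCC/C1=N\C(=O)Nc1cccc(I)c1`, has not yet been measured. It differs from compound 1 by one change: iodo in place of hydrogen on an aromatic carbon. Among the compounds with values here, with no measured step to lean on, the most defensible expectation is a change of no size beyond the usual scatter, with the risk that the value again ends as a limit rather than a number, as it does for compound 2 and compound 3.

Compound 4 is therefore expected to give 20 mg/kg, in a range from 8 mg/kg to 50 mg/kg. That estimate means an expected step of a 1.3-fold higher number from compound 1 to compound 4 (0.12 log units; within the scatter), within the scatter of repeated measurements.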

Compound 4, minimum effective dose: > 25 mg/kg
Compound 4 was reported as a limit; the forecaster's own chance of this, stated with the estimate: 40%; middle value at least 1.2-fold (0.09 log units) from the limit.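

For the compounds shown here, compound 4 is the first compound here that differs from compound 1 in one place only, so the iodo group, on an aromatic carbon and meta to a large group, can be read on its own. In this assay, this single change gives an at least 1.6-fold higher number from compound 1 to compound 4 (0.22 log units; that floor lies within the scatter). The step has only a floor, so it shows that this change did not preserve a defined minimum effective dose within the tested range, but it does not establish a true shift beyond ordinary variation, and compound 4 now joins the other compounds at the same ceiling: the limit of > 25 mg/kg in this assay, at which 3 of the 4 values shown sit.

The true size of the step stays open, since the value of compound 4 is a limit and not a number, and the compounds shown cannot tell whether the outcome is particular to iodo or holds for any group at this place. Whether a fluoro, methoxy or amino group on the same aromatic carbon would return a defined dose is also unresolved, as is the outcome for iodo elsewhere on the six-membered aromatic ring.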